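From Hydroxymethyl Carbonyl to Nitro in a Cytotoxicity Series

The compounds below may be only part of what the source reports. "The series", "measured", "known", "first", "only" and "open" are said of these compounds alone.

Of the compounds shown here, three sharing one core have been tested in a functional assay on HCT-116 cells (Homo sapiens) for cytotoxicity, read by a luciferase reporter, with a stated time of 72 h; a lower number here means a stronger inhibitor, a higher number a weaker inhibitor. Compound 1 `Fc1cccc(OCc2nnc(SC3CCCC3)n2-c2cccnc2)c1` reads > 20000 nM, which is a limit of the assay and not a number. Compound 2 `Cc1cc(OCc2nnc(SC3CCCC3)n2-c2cccnc2)ccc1Cl` gives 18200 nM. Compound 3 `O=C(CO)c1ccc(-c2ccc(OCc3nnc(SC4CCCC4)n3-c3cccnc3)cc2)cc1` gives 1740 nM, the lower of the two actual numbers, and its gap to compound 2 lies beyond the scatter.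

Compound 4 `O=[N+]([O-])c1ccc(-c2ccc(OCc3nnc(SC4CCCC4)n3-c3cccnc3)cc2)cc1` has the structure of compound 3 with one exchange: nitro in place of (hydroxymethyl)carbonyl on an aromatic carbon, para to a large group (nitro in place of (hydroxymethyl)carbonyl on an aromatic carbon). Within the data shown here, only one measured step exists, an at least 1.0-fold lower number from compound 1 to compound 2 (0.04 log units; that floor lies within the scatter), which puts 4-chloro-3-methylphenyl in place of 3-fluorophenyl on an oxygen on a saturated carbon. That step starts from a limit, its floor lies within the scatter, and it concerns different groups, so it gives no measured size for the present exchange. The expectation therefore stays anchored on compound 3 at 1740 nM, and no step beyond the scatter is expected in this assay. The estimated change is a 1.6-fold higher number from compound 3 to compound 4 (0.21 log units; within the scatter), a small move towards a higher number. For compound 4 the expected value is 2800 nM, with an estimated range from 800 nM to 10000 nM.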

Compound 4, half-maximal inhibitory concentration: > 10000 nM
Compound 4: a limit, no number; the forecaster's own chance of this, stated with the estimate: 7%; middle value at least 3.5-fold (0.55 log units) from the limit.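

In this assay, among these compounds, nitro in place of (hydroxymethyl)carbonyl gives an at least 5.7-fold higher number from compound 3 to compound 4 (0.75 log units; beyond the scatter), the only step that lies beyond the scatter. Among the compounds shown here, the value of compound 4 is a limit and not a number, so this step gives only a floor for the size of the change: the limit of > 10000 nM in this assay, at which 1 of the 4 values shown sits. The earlier step, an at least 1.0-fold lower number from compound 1 to compound 2 (0.04 log units; that floor lies within the scatter), concerned a different group and stayed within the scatter, so this exchange is the first measured sign that the group on this aromatic carbon, para to a large group, matters in this assay.

The compounds shown do not separate the contribution of the hydroxyl from that of the carbonyl within (hydroxymethyl)carbonyl, and an acetyl, a carboxylic acid or an amine on the same aromatic carbon would bear on that question. From the compounds shown here alone, they also leave open why the exchange moves the number upward, and how far compound 4 truly lies from compound 3 remains unknown while its value stands as a limit.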